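Swapping 1-benzofuran-2-yl for ethynyl: what to expect

The source may report more compounds than this note shows. Statements on the series, on what has been measured and on what is new or still open speak of the compounds shown alone.

In a functional assay on HCT-116 cells (Homo sapiens), read by MTT assay, with a stated time of 72 h (a higher number here means a weaker inhibitor, a lower number a stronger inhibitor), compound 1 (`COc1ncnc2c1c(-c1ccccc1)cn2[C@@H]1O[C@H](CO)[C@@H](O)[C@H]1O`) gives > 20000 nM, which is a limit of the assay. Among the compounds with values here, compound 2 (`COc1ncnc2c1c(-c1cc3ccccc3o1)cn2[C@@H]1O[C@H](CO)[C@@H](O)[C@H]1O`) gives 13800 nM, the only actual number so far. Compound 3 (`C#Cc1cn([C@@H]2O[C@H](CO)[C@@H](O)[C@H]2O)c2ncnc(OC)c12`) has ethynyl in place of 1-benzofuran-2-yl on an aromatic carbon. Within the data shown here, the one measured step, an at least 1.4-fold lower number from compound 1 to compound 2 (0.16 log units; that floor lies within the scatter), exchanged one ring group for another and has a floor within the scatter, so it offers only weak guidance. The expected change in this assay is a modest move to a lower number, a 2.3-fold lower number from compound 2 to compound 3 (0.36 log units; beyond the scatter). For compound 3 the estimated value is 6000 nM, with a range of 800 nM to 20000 nM.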

Compound 3, half-maximal inhibitory concentration: 4060 nM
Estimate against measurement, compound 3: 1.5-fold (0.17 log units) above, and the stated range covers the measured number.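

Moving to ethynyl gives a 3.4-fold lower number from compound 2 to compound 3 (0.53 log units; beyond the scatter), and an at least 4.9-fold lower number from compound 1 to compound 3 (0.69 log units; beyond the scatter). Within the data shown here, these are the first steps at this aromatic carbon that lie beyond the scatter, and they show that in this assay a ring group is not needed here, since ethynyl has no ring and gives the lowest number of the three. The second step is only a floor, as the value of compound 1 is a limit: the limit of > 20000 nM in this assay, at which 1 of the 3 values shown sits.

From the compounds shown here alone, how an ethyl group, a longer alkyne chain or an amine would fare at this carbon remains open. The triple bond and the absence of a ring therefore cannot yet be told apart.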